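Removing One Hydroxy Group From Compound 1

The source may hold more compounds than are shown below. What is called first, only, known or untested is meant among the compounds shown, and "the series" means these compounds.

Compound 1 `COc1cc(-c2ccccc2)cc(O)c1O` was examined in a functional assay on HCT-15 cells (Homo sapiens) for cytotoxicity, read by sulforhodamine B assay; on this read-out lower numbers stand for stronger inhibition and higher numbers for weaker inhibition. In this assay compound 1 gives > 10000 nM, which is a limit of the assay rather than a number. Two related compounds were measured alongside it. Compound 2 `COc1cc(-c2ccccc2)cc(OC)c1OC` in this assay gives > 10000 nM, again a limit. Compound 3 `COc1cc(OC)cc(-c2ccccc2O)c1` in this assay gives > 10000 nM, also a limit. Compound 1 thus stands at the limit of > 10000 nM in this assay, at which 3 of the 3 values shown sit; none of the three carries a measured number, and no ordering among them can be drawn from these results.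

Compound 4 `COc1cc(O)cc(-c2ccccc2)c1` has not yet been measured in this assay. It differs from compound 1 in one place: hydrogen in place of hydroxy on an aromatic carbon. Among the compounds with values here, no pair of measured compounds differing in a single place is available, so the size of this kind of step in this assay is not known from the data. Because compound 1 sits at the limit of > 10000 nM in this assay, at which 3 of the 3 values shown sit, the most the change can be expected to do is stay within the scatter or move in either direction without leaving the limit. The estimated step in this assay is a step that the limit leaves unreadable from compound 1 to compound 4, which is expected to be no larger than the usual scatter. Compound 4 is therefore expected to give 20000 nM in this assay, with a range from 8000 nM to 60000 nM.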

Compound 4, half-maximal inhibitory concentration: > 10000 nM
Compound 4: a limit, no number (the forecaster's own chance of this, stated with the estimate: 85%); the middle value lies beyond the limit too.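

The step from compound 1 to compound 4 cannot be read in this assay, because both results are limits of the assay and not numbers: the limit of > 10000 nM in this assay, at which 4 of the 4 values shown sit.

The compounds shown leave open whether hydrogen in place of hydroxy changes the cytotoxicity at all, since none of them gives a measured number in this assay.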